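Capping an Amine with Acetyl: What Cytotoxicity to Expect

The source may report more compounds than this note shows. Statements on the series, on what has been measured and on what is new or still open speak of the compounds shown alone.

Three related compounds have been tested in an ADME assay on BHK cells (Mesocricetus auratus) for cytotoxicity, read by MTT assay, with a stated time of 96 h; on this read-out higher numbers stand for lower toxicity in this test and lower numbers for higher toxicity in this test. Compound 1 `CN1CCN(CC(=O)Nc2ccc(-c3nc4cc(Cl)c(Cl)cc4[nH]3)cc2)CC1` gives 41000 nM. Compound 2 `Nc1ccc(-c2nc3cc(Cl)c(Cl)cc3[nH]2)cc1` gives 30000 nM, the lowest of the three numbers; compound 1 lies close to it, within the scatter, while compound 3 `Cn1c(-c2ccc(NC(=O)CN3CCN(c4ccccc4)CC3)cc2)nc2cc(C(F)(F)F)ccc21`, with 100000 nM, sits beyond the scatter. Compound 4 `CC(=O)Nc1ccc(-c2nc3cc(Cl)c(Cl)cc3[nH]2)cc1` has not yet been measured and differs from compound 2 in a single place: acetyl in place of hydrogen on a nitrogen on an aromatic ring. Compound 1 also carries an amide where compound 2 has a free amine, and its number stays within the scatter of compound 2 in this assay. A small step is therefore expected from compound 2 to compound 4, a 1.3-fold higher number from compound 2 to compound 4 (0.10 log units; within the scatter), upward at most slightly and not clearly beyond the scatter. Compound 4 is estimated at 38000 nM, within 18000 nM to 80000 nM.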

Compound 4, half-maximal cytotoxic concentration: > 100000 nM
Compound 4 was reported as a limit; the forecaster's own chance of this, stated with the estimate: 5%; at least 2.6-fold (0.42 log units) between middle value and limit.
By their numbers in this assay, from the lowest: compounds 2 and 1 (each within the scatter of the next); then compound 3.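

On the nitrogen on the aromatic ring, acetyl in place of hydrogen is a real change in this assay, pointing to lower toxicity in this test: an at least 3.3-fold higher number from compound 2 to compound 4 (0.52 log units; beyond the scatter)). Hydrogen in place of 4-methylpiperazin-1-yl on the saturated chain carbon bound to a carbonyl carbon also matters, so the amide alone does not set the number: an at least 2.4-fold higher number from compound 1 to compound 4 (0.38 log units; beyond the scatter)). Compound 4 gives > 100000 nM, which is a limit and not a number: the limit of > 100000 nM in this assay, at which 1 of the 4 values shown sits.

Going by these compounds, the true size of both steps stays open. So does the effect of a longer chain such as propionyl on that nitrogen, or of a smaller amine such as dimethylamino on the chain.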